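Fluoro in place of methoxy at one aromatic position

This account rests on a few compounds, and the source may have more. Where it says the series, first, only, none or still open, it means among the compounds named here.

Compound 1 `COc1ccc(S(=O)(=O)Nc2ccc(-c3nc4ccccc4o3)cc2)cc1`: in an assay on isolated protein for inhibition of malate dehydrogenase, mitochondrial (Sus scrofa), with stated times of 45 min and 30 min (a lower number here means a stronger inhibitor, a higher number a weaker inhibitor), compound 1 gives > 63000 nM.
Compound 2 `O=S(=O)(Nc1ccc(-c2nc3ccccc3o2)cc1)c1ccc(Cl)c(C(F)(F)F)c1`: in this assay compound 2 gives > 63000 nM.

Both readings are limits of the assay rather than numbers. For compound 1 the reading > 63000 nM is such a limit. For compound 2 the reading > 63000 nM is likewise a limit. Compound 1 therefore stands at the limit of > 63000 nM in this assay, at which 2 of the 2 values shown sit. Going by the values given here, no step between two measured compounds is known here, so the structural change itself is the only guide.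

Compound 3 `O=S(=O)(Nc1ccc(-c2nc3ccccc3o2)cc1)c1ccc(F)cc1` has not yet been measured in this assay. It differs from compound 1 in one place: fluoro in place of methoxy on an aromatic carbon. What leaves and what enters are both small, and the shared core of compound 1 is kept entirely. Among the compounds with values here, with no measured step to lean on, the expected step is none beyond the scatter. The expected step is a number no higher from compound 1 to compound 3 (the limit leaves the size open). Compound 3 is expected to give 63000 nM, between 20000 nM and 200000 nM. This rests on compound 1, whose reading > 63000 nM is a limit, so the assay will most likely again report only a limit for compound 3.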

Compound 3, half-maximal inhibitory concentration: > 63000 nM
Compound 3 gave a limit, no number (the forecaster's own chance of this, stated with the estimate: 80%); the middle value sits exactly at the limit.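

No step can be read from compound 1 to compound 3, because both readings are limits of the assay and not numbers: the limit of > 63000 nM in this assay, at which 3 of the 3 values shown sit.

The compounds shown leave open how 4-methoxyphenyl and 4-fluorophenyl compare, and whether any close relative of these compounds would give a readable number in this assay.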